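Swapping the Aryl Group on the Ring Nitrogen

The source may report more compounds than this note shows. Statements on the series, on what has been measured and on what is new or still open speak of the compounds shown alone.

Measured in a functional assay on MCF7 cells (Homo sapiens) for cytotoxicity, read by MTT assay, with a stated time of 96 h; on this read-out lower numbers stand for stronger inhibition and higher numbers for weaker inhibition:
- compound 1 `COc1cc(C(=O)c2cn(-c3cccc(N)c3)cc2-c2ccccc2Cl)cc(OC)c1OC`: 40 nM
- compound 2 `COc1cc(C(=O)c2cn(-c3cccc(N)c3)cc2-c2cccc([N+](=O)[O-])c2)cc(OC)c1OC`: 510 nM

Compound 2, at 510 nM, has the higher of the two numbers and is the weaker of the pair. Compound 3 `COc1cc(C(=O)c2cn(-c3ccc(F)cc3)cc2-c2cccc([N+](=O)[O-])c2)cc(OC)c1OC` has not been measured yet. It keeps the 3-nitrophenyl group of compound 2 but differs by 4-fluorophenyl in place of 3-aminophenyl on an aromatic nitrogen. Among the compounds with values here, the only measured step, a 13-fold higher number from compound 1 to compound 2 (1.11 log units; beyond the scatter), changed a group on an aromatic carbon, so no measured step covers this swap. Within the data shown here, that step shows only that one swap on the shared core can be large. The direction is therefore a cautious guess: a moderate rise in this assay, smaller than that step. The expected change is a 2.4-fold higher number from compound 2 to compound 3 (0.37 log units; beyond the scatter). For compound 3 the estimated value is 1200 nM, with an expected range of 300 nM to 5000 nM.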

Compound 3, half-maximal inhibitory concentration: 440 nM
For compound 3 the middle estimate is 2.7-fold (0.44 log units) above the measured one; low and high end bracket the measured number.
By their numbers in this assay, from the lowest: compound 1; then compounds 3 and 2 (each within the scatter of the next).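

In this assay, exchanging the aryl group on the ring nitrogen gives a 1.2-fold lower number from compound 2 to compound 3 (0.06 log units; within the scatter), so with the 3-nitrophenyl group held in place, 3-aminophenyl and 4-fluorophenyl cannot be told apart at this position. This step on the aromatic nitrogen stays within the scatter, even though 3-aminophenyl carries 1 hydrogen-bond donor and 1 hydrogen-bond acceptor while 4-fluorophenyl carries 0 of each, and it contrasts with the large step on the aromatic carbon, a 13-fold higher number from compound 1 to compound 2 (1.11 log units; beyond the scatter). No measurement here explains why these two groups read alike.

The compounds shown pair 4-fluorophenyl only with 3-nitrophenyl, so it remains open whether the same holds alongside the 2-chlorophenyl group of compound 1. Also open, from the compounds shown here alone, is how a carboxylic acid on this phenyl ring, or a cyclohexyl ring or longer alkyl chain in its place, would read.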